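This account rests on a few compounds, and the source may have more. Where it says the series, first, only, none or still open, it means among the compounds named here.

Within the data shown here, in a functional assay on U-87MG ATCC cells for cytotoxicity against U-87 MG (Homo sapiens), read by MTT assay, with a stated time of 72 h (on this read-out lower numbers stand for stronger inhibition and higher numbers for weaker inhibition), compound 2 `COc1ncc(-c2ccc3nc(NC(=O)NCC(=O)N4CCOCC4)nn3c2)cc1NS(=O)(=O)c1ccc(F)cc1` gives 3260 nM, the higher of the two numbers measured so far, and compound 1 `COc1ncc(-c2ccc3nc(NC(=O)NC4CC4)nn3c2)cc1NS(=O)(=O)c1ccc(F)cc1` gives 540 nM. The next compound, compound 3 `COc1ncc(-c2ccc3nc(NC(=O)NCCN4CCN(C)CC4)nn3c2)cc1NS(=O)(=O)c1ccc(F)cc1`, differs from compound 2 in one place: (4-methylpiperazin-1-yl)methyl in place of (morpholin-4-yl)carbonyl on a saturated chain carbon bound to an amide-type nitrogen. Put simply, (4-methylpiperazin-1-yl)methyl takes the place of (morpholin-4-yl)carbonyl on a saturated chain carbon bound to an amide-type nitrogen. Among the measured compounds shown here, no measured step tests this exchange directly. The closest evidence is a 6.0-fold higher number from compound 1 to compound 2 (0.78 log units; beyond the scatter), which came with the arrival of the (morpholin-4-yl)carbonyl group that compound 3 gives up. On that single step, a modest move towards lower numbers is expected in this assay, though the direction is uncertain. This estimate amounts to an expected 2.2-fold lower number from compound 2 to compound 3 (0.34 log units; beyond the scatter). For compound 3, the expected value is 1500 nM, within an estimated range of 450 nM to 5000 nM.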

Compound 3, half-maximal inhibitory concentration: 760 nM
Compound 3: middle estimate off by 2.0-fold (0.30 log units), on the high side; measured number inside the range.
By their numbers in this assay, from the lowest: compounds 1 and 3 (each within the scatter of the next); then compound 2.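

In this assay the exchange of (morpholin-4-yl)carbonyl for (4-methylpiperazin-1-yl)methyl gives a 4.3-fold lower number from compound 2 to compound 3 (0.63 log units; beyond the scatter) even though both groups have the same heavy-atom count and a six-membered non-aromatic ring, so those shared features alone do not set the number here. Against cyclopropyl on the amide-type nitrogen, the 2-(4-methylpiperazin-1-yl)ethyl group gives a 1.4-fold higher number from compound 1 to compound 3 (0.15 log units; within the scatter) and so cannot be told apart from it in this assay. No measurement available here explains the difference between compound 2 and compound 3.

Compound 3 loses the carbonyl and gains the methylpiperazine ring in one exchange, so the two changes remain entangled. A 2-(morpholin-4-yl)ethyl group would separate them, and a 2-(dimethylamino)ethyl group would ask whether any ring is needed.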